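The source may hold more compounds than are shown below. What is called first, only, known or untested is meant among the compounds shown, and "the series" means these compounds.

Three compounds share one core and differ only in the group carried on an aromatic carbon of the ring attached to it. Compound 1 `CC(C)c1ccc(N2C(=O)C=CC2OCC(F)(F)F)cc1` gives 9570 nM in a functional assay on A549 cells (Homo sapiens) for inhibition; a higher number here means a weaker inhibitor, a lower number a stronger inhibitor. Compound 2 `Cc1ccc(N2C(=O)C=CC2OCC(F)(F)F)cc1` gives 13700 nM in this assay, and compound 3 `O=C1C=CC(OCC(F)(F)F)N1c1ccc([N+](=O)[O-])cc1` gives 3270 nM in this assay. Compound 3 stands lowest of the three numbers: the steps to it are a 2.9-fold lower number from compound 1 to compound 3 (0.47 log units; beyond the scatter) and a 4.2-fold lower number from compound 2 to compound 3 (0.62 log units; beyond the scatter), both beyond the scatter, whereas a 1.4-fold higher number from compound 1 to compound 2 (0.16 log units; within the scatter) stays within it.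

Compound 4 `O=C1C=CC(OCC(F)(F)F)N1c1ccc(Br)cc1` has not yet been measured. It differs from compound 3 in one place: bromo in place of nitro on an aromatic carbon. The two measured steps that end at compound 3 both put nitro in place of a small alkyl group at this carbon and lowered the number by a modest amount. Within the data shown here, no measured step involves bromo, so nothing shows directly how it compares with nitro or with the alkyl groups. Since the nitro group accompanied the lowest number seen, its removal is expected to move the number back upward, though perhaps not fully to where compound 1 and compound 2 stand; the expected step is a 2.0-fold higher number from compound 3 to compound 4 (0.30 log units; within the scatter). The estimate for compound 4 in this assay is therefore 6500 nM, expected to fall between 2500 nM and 16000 nM.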

Compound 4, half-maximal inhibitory concentration: 6960 nM
Compound 4: the middle estimate sits 1.1-fold (0.03 log units) below what was measured, and the stated range covers the measured number.
By their numbers in this assay, from the lowest: compound 3; then compounds 4, 1 and 2 (each within the scatter of the next).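

Bromo does not hold the number where nitro had it, with a 2.1-fold higher number from compound 3 to compound 4 (0.33 log units; beyond the scatter) in this assay, so compound 3 remains the strongest inhibitor of the four, its steps to all the others lying beyond the scatter. The other two new steps, a 2.0-fold lower number from compound 2 to compound 4 (0.29 log units; within the scatter) and a 1.4-fold lower number from compound 1 to compound 4 (0.14 log units; within the scatter), both lie within the scatter, which places bromo alongside methyl and isopropyl, so at this carbon these three groups cannot be told apart and only nitro stands out. The change also removes the hydrogen-bond acceptors of nitro and brings in a group with none, but no measurement at hand explains why nitro stands apart.

From the compounds shown here alone, it remains open whether nitro is unique at this carbon, or whether a nitrile, a carboxylic acid or an amine would give a number near that of compound 3 or one nearer the other three. All four compounds also keep the same shared core, so whether the difference between nitro and the other groups would persist with a longer chain in place of the 2,2,2-trifluoroethoxy group is also unknown.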